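A shorter chain with a double bond

The source may hold more compounds than are shown below. What is called first, only, known or untested is meant among the compounds shown, and "the series" means these compounds.

Measured in a toxicity assay on cells (Erythrocyte, Homo sapiens) for cytotoxicity, read by hemolysis; a higher number here means that more compound is needed for the effect, a lower number that less compound is needed:
- Compound 1 `CCCCCC(=O)NCc1ccc(C(=O)N[C@H](C(=O)O)[C@@H](C)CC)cc1`: > 1500 ug/mL (a limit, not a number)
- Compound 2 `CCCCCCCCCCCCCCCC(=O)NCc1ccc(C(=O)N[C@H](C(=O)O)[C@@H](C)CC)cc1`: 50 ug/mL

Among the compounds with values here, compound 2, at 50 ug/mL, holds the only true number so far. Compound 3 `CCCC/C=C\CCCCCCCC(=O)NCc1ccc(C(=O)N[C@H](C(=O)O)[C@@H](C)CC)cc1` differs from it in the chain: hex-1-en-1-yl in place of octyl on a saturated chain carbon, seven bonds along the chain from a carbonyl carbon. Within the data shown here, one measured step bears on this: an at least 30-fold lower number from compound 1 to compound 2 (1.47 log units; beyond the scatter), a large change that came with adding decyl to the chain. Going from octyl to hex-1-en-1-yl undoes only a modest part of that addition, and the double bond has no measured precedent. The expected change is a 5.0-fold higher number from compound 2 to compound 3 (0.70 log units; beyond the scatter), a clear move towards a higher number in this assay. The estimate for compound 3 is 250 ug/mL, with an expected range of 90 ug/mL to 800 ug/mL.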

Compound 3, half-maximal effective concentration: 350 ug/mL
The estimate for compound 3 lay 1.4-fold (0.15 log units) below the measured number; measured number inside the range.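

In this assay, putting hex-1-en-1-yl in place of octyl at this place gives a 7.0-fold higher number from compound 2 to compound 3 (0.85 log units; beyond the scatter), so compound 3 needs more compound for the effect than compound 2. Compound 3 still gives a lower number than the short chain of compound 1, with an at least 4.2-fold lower number from compound 1 to compound 3 (0.63 log units; beyond the scatter). Compound 1 stands at a limit, not a number, so that step is only a bound: the limit of > 1500 ug/mL in this assay, at which 1 of the 3 values shown sits.

As far as these compounds go, the shortening and the double bond arrive together in compound 3, and their separate shares stay open. A fully saturated chain of the same length would separate them.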